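The source may hold more compounds than are shown below. What is called first, only, known or untested is meant among the compounds shown, and "the series" means these compounds.

Compound 2 `O=C1c2ccc(Cl)cc2C(C2CC2)N1c1cccnc1` is the only one of the three measured compounds to give an actual number in an ADME assay on microsomes from liver (Homo sapiens) for metabolic stability, read by LC-MS, using NADPH, with stated times of 10 min and 30 min (on this read-out lower numbers stand for slow clearance and higher numbers for fast clearance), where compound 2 gives 9.4 mL/min/kg. Compound 1 `CC[C@H]1c2cc(Cl)ccc2C(=O)N1c1cncc2c1CCC[C@H]2NC(C)=O` gives only a limit of this assay, < 3.5 mL/min/kg. Compound 3 `CCC(=O)N[C@@H]1CCCc2c1cncc2N1C(=O)c2ccc(Cl)cc2[C@@H]1CC` likewise gives only a limit, < 3.5 mL/min/kg; both sit at the limit of < 3.5 mL/min/kg in this assay, at which 2 of the 3 values shown sit. Going by the values given here, the one measured step, a step that the two limits leave unreadable from compound 1 to compound 3, therefore cannot be read in size. Compound 4 `O=C1c2ccc(Cl)cc2CN1c1cccnc1` differs from compound 2 by hydrogen in place of cyclopropyl on a saturated ring carbon. Among the compounds with values here, no measured step bears on this change, so there is no ground to expect a step beyond the scatter, in either direction. Compound 4 is therefore expected to give about 9 mL/min/kg in this assay, within 4 mL/min/kg to 20 mL/min/kg. The expected step is a 1.0-fold lower number from compound 2 to compound 4 (0.02 log units; within the scatter).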

Compound 4, clearance: 12.8 mL/min/kg
The estimate for compound 4 lay 1.4-fold (0.15 log units) below the measured number; the measured number falls inside the stated range.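

In this assay, hydrogen in place of cyclopropyl on this saturated ring carbon gives a 1.4-fold higher number from compound 2 to compound 4 (0.13 log units; within the scatter). Going by these compounds alone, this is the first step that can be read, since the step between the two compounds held at limits cannot, and it shows that cyclopropyl can leave this position with no shift beyond the scatter. Nothing measured here gives a cause for this result. From the compounds shown here alone, whether a primary amine or a carboxylic acid on the same carbon would also stay within the scatter remains open. So does whether a longer chain there would.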